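This account rests on a few compounds, and the source may have more. Where it says the series, first, only, none or still open, it means among the compounds named here.

Measured so far: compound 1 `COc1cc(N2C(=O)C(O)C2c2ccc(SC)cc2)cc(OC)c1OC` gives 15 nM in a functional assay on HL-60 cells (Homo sapiens) for inhibition, read by resazurin assay, with a stated time of 72 h; a lower number here means a stronger inhibitor, a higher number a weaker inhibitor; compound 2 `COc1ccc(C2C(O)C(=O)N2c2cc(OC)c(OC)c(OC)c2)cc1O` gives 5 nM in this assay.

Compound 1 stands highest of the two numbers; its nearest neighbour is compound 2, with a 3.0-fold lower number from compound 1 to compound 2 (0.48 log units; beyond the scatter) on exchange of the aryl group. Compound 3 `COc1cc(N2C(=O)CC2c2ccc(SC)cc2)cc(OC)c1OC` differs from compound 1 elsewhere: hydrogen in place of hydroxy on a saturated ring carbon. Among the measured compounds shown here, no measured step touches this position, so the single step in hand offers no guide to direction or size. A step beyond the scatter is plausible but unsupported either way; compound 3 is therefore expected near compound 1, with a 2.7-fold higher number from compound 1 to compound 3 (0.43 log units; beyond the scatter) as the working guess. Compound 3 is estimated at 40 nM in this assay, within 10 nM to 200 nM.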

Compound 3, half-maximal inhibitory concentration: 69 nM
Estimate against measurement, compound 3: 1.7-fold (0.24 log units) below, and the stated range covers the measured number.
By their numbers in this assay, from the lowest: compound 2; then compound 1; then compound 3.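

In this assay, hydrogen in place of hydroxy on the saturated ring carbon gives a 4.6-fold higher number from compound 1 to compound 3 (0.66 log units; beyond the scatter). This position therefore responds to the change, and of this pair the hydroxy-bearing compound 1 holds the lower number. Nothing at hand accounts for the direction or size of this step.

Open, going by these compounds, is how an amine or a methoxy group on this carbon would compare with hydroxy and hydrogen. Also open, on these data alone, is whether the same exchange gives a similar step with the 3-hydroxy-4-methoxyphenyl group of compound 2.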